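Benzyl for pyridin-2-yl on the azole nitrogen

The compounds below may be only part of what the source reports. "The series", "measured", "known", "first", "only" and "open" are said of these compounds alone.

Compound 2 `Nc1cc(Cc2ccn(-c3ccccn3)n2)c2nn[nH]c2n1` gives 2000 nM in an assay on cells for inhibition of thyroid peroxidase (Homo sapiens), with stated times of 10 min and 15 min; on this read-out lower numbers stand for stronger inhibition and higher numbers for weaker inhibition. Among the three measured compounds it holds the second highest number: compound 3 `Nc1cc(Cc2ccn(Cc3ccc4cnccc4c3)n2)c2nn[nH]c2n1` gives 1800 nM in this assay, a gap within the usual scatter, while compound 1 `Nc1cc(Cc2ccn(Cc3ccc4c(c3)CCNC4)n2)c2nn[nH]c2n1` gives 6700 nM, a gap beyond it. The unmeasured compound 4 `Nc1cc(Cc2ccn(Cc3ccccc3)n2)c2nn[nH]c2n1` differs from compound 2 in one place (benzyl in place of pyridin-2-yl on an aromatic nitrogen), with a benzyl group in place of the pyridin-2-yl group. For the measured compounds named here, no measured pair shows this exact change, so the expectation rests on the spread of the three numbers alone; a step of no more than the scatter is expected, a 1.5-fold higher number from compound 2 to compound 4 (0.18 log units; within the scatter). Compound 4 is estimated at 3000 nM, within 1000 nM to 9000 nM.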

Compound 4, half-maximal inhibitory concentration: 2300 nM
Estimate against measurement, compound 4: 1.3-fold (0.12 log units) above; the measured number falls inside the stated range.
By their numbers in this assay, from the lowest: compounds 3, 2 and 4 (each within the scatter of the next); then compound 1.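

In this assay, benzyl in place of pyridin-2-yl on the aromatic nitrogen gives a 1.2-fold higher number from compound 2 to compound 4 (0.06 log units; within the scatter). This first matched pair shows that, at this position, swapping pyridin-2-yl with its ring nitrogen for the all-carbon benzyl group produces no step beyond the scatter. No supporting measurement is available to explain this result. On these data alone, whether an amine, a carboxylic acid or a longer chain on this aromatic nitrogen would give a step beyond the scatter stays open.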